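Moving from 3-chlorophenyl to 4-chlorophenyl

The source may report more compounds than this note shows. Statements on the series, on what has been measured and on what is new or still open speak of the compounds shown alone.

Three compounds that share one core and differ only in the substituted phenyl group have been measured in a functional assay on MCF7 cells (Homo sapiens) for cytotoxicity, read by sulforhodamine B assay; a lower number here means a stronger inhibitor of growth, a higher number a weaker inhibitor of growth. Here compound 1 `CC1=CC[C@@H]([C@@](C)(O)CCCC(C)(C)NC(=S)N/N=C\c2ccc(C)cc2)CC1` gives 7230 nM, compound 2 `CC1=CC[C@@H]([C@@](C)(O)CCCC(C)(C)NC(=S)N/N=C\c2ccccc2[N+](=O)[O-])CC1` gives 18600 nM and compound 3 `CC1=CC[C@@H]([C@@](C)(O)CCCC(C)(C)NC(=S)N/N=C\c2cccc(Cl)c2)CC1` gives 7350 nM. Compound 3 thus stands level with compound 1, while compound 2 alone carries a clearly higher number.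

The next compound, compound 4 `CC1=CC[C@@H]([C@@](C)(O)CCCC(C)(C)NC(=S)N/N=C\c2ccc(Cl)cc2)CC1`, has 4-chlorophenyl in place of 3-chlorophenyl on a carbon with a double bond to nitrogen. Among the measured compounds shown here, no measured pair tests this kind of swap directly, so the evidence is indirect. The nearest guide is the change from 4-methylphenyl to 3-chlorophenyl, a 1.0-fold higher number from compound 1 to compound 3 (0.01 log units; within the scatter). The two larger steps, a 2.6-fold higher number from compound 1 to compound 2 (0.41 log units; beyond the scatter) and a 2.5-fold lower number from compound 2 to compound 3 (0.40 log units; beyond the scatter), both involve the 2-nitrophenyl group, which compound 4 does not carry. They do show that this series can move when the phenyl group changes, so the range should stay wide. In this assay no step beyond the scatter is expected, and the estimated change is a 1.0-fold higher number from compound 3 to compound 4 (0.01 log units; within the scatter). Compound 4 is therefore expected to give about 7500 nM, within an estimated range of 4000 nM to 14000 nM.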

Compound 4, concentration for 50% growth inhibition: 6890 nM
The estimate for compound 4 lay 1.1-fold (0.04 log units) above the measured number, and the stated range covers the measured number.
By their numbers in this assay, from the lowest: compounds 4, 1 and 3 (each within the scatter of the next); then compound 2.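

In this assay, 4-chlorophenyl in place of 3-chlorophenyl gives a 1.1-fold lower number from compound 3 to compound 4 (0.03 log units; within the scatter), so this direct test of where the chloro group sits on the phenyl ring does not separate these two compounds. The comparison of chloro with methyl on an aromatic carbon gives a 1.0-fold lower number from compound 1 to compound 4 (0.02 log units; within the scatter), which means that these two groups, both on 4-substituted phenyl rings, cannot be told apart here either. Against this flat set of compounds 1, 3 and 4, the change from 2-nitrophenyl to 4-chlorophenyl still gives a modest step beyond the scatter (a 2.7-fold lower number from compound 2 to compound 4 (0.43 log units; beyond the scatter)), so compound 2 remains the only one that stands apart.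

The compounds shown leave open whether the nitro group itself or its place on the phenyl ring sets compound 2 apart, and how a phenyl ring carrying an amine or a carboxylic acid would behave in this assay. Nothing measured here explains why the numbers stay level or why compound 2 differs.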